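This account rests on a few compounds, and the source may have more. Where it says the series, first, only, none or still open, it means among the compounds named here.

In an ADME assay (Mus musculus, strain C57BL/6) for metabolic stability, read by HPLC, with a stated time of 12 h (on this read-out higher numbers stand for a longer-lived compound and lower numbers for a shorter-lived compound), compound 1 `O=C(O)[C@H](CO)NC(=O)[C@H]1C[C@H](O)CN1` gives > 12 h as a limit of the assay. Compound 2 `O=C(O)[C@@H](CO)NC(=O)[C@H]1C[C@H](O)CN1` gives > 12 h as a limit too. For compound 3 `O=C(N[C@H](CO)C(=O)O)[C@@H]1C[C@@H](O)CN1` the change from compound 2 is that the two compounds have the same atoms and bonds and differ only in configuration as drawn: 2 of 3 stereo elements differ; a stereocentre at a saturated ring carbon is drawn R in compound 2 and S in compound 3; a stereocentre at a saturated ring carbon is drawn S in compound 2 and R in compound 3 and the chain stereocentre stays as drawn. Within the data shown here, the one measured step is a step that the two limits leave unreadable from compound 1 to compound 2 and it touches a saturated chain carbon, not the ring carbons, so it offers no size to carry over. Compound 2 shares the limit of > 12 h in this assay, at which 2 of the 2 values shown sit, and no step beyond the scatter is expected in either direction. The estimated step is a step that the limit leaves unreadable from compound 2 to compound 3 with no direction favoured. Compound 3 is expected near 14 h with 8 h to 24 h as the estimated range.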

Compound 3, half-life: 0.91 h
The estimate for compound 3 lay 15-fold (1.19 log units) above the measured number; the whole stated range lies above it.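

In this assay, inverting both ring stereocentres while the chain stereocentre stays as drawn gives an at least 13-fold lower number from compound 2 to compound 3 (1.12 log units; beyond the scatter), whereas the earlier change at the chain stereocentre alone left no readable step. Inverting all three stereo elements gives an at least 13-fold lower number from compound 1 to compound 3 (1.12 log units; beyond the scatter). No atoms or bonds change, so configuration alone separates these compounds: the fact that compounds 2 and 3 differ only in the configuration as drawn

On these data alone, whether either ring stereocentre alone would produce such a step remains open. So does whether the same step would appear with an amine or a fluorine in the shared core.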